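From an Azido Alcohol Chain to Plain Propyl

The compounds below may be only part of what the source reports. "The series", "measured", "known", "first", "only" and "open" are said of these compounds alone.

Compound 1 `[N-]=[N+]=NCC(O)Cn1c(=O)n(C2OC(CO)[C@@H](O)[C@H]2O)c2nc(N)nc(O)c21` was measured in a functional assay on the whole organism (B cells) with Mus musculus as the target (on this read-out higher numbers stand for larger maximal responses and lower numbers for smaller maximal responses), and gives 91%. Of the two measured compounds it stands lowest; its nearest neighbour is compound 2 `C=CCn1c(=O)n(CCCCCCCC)c2nc(N)nc(O)c21`, which in this assay reaches 130%, a gap beyond the usual scatter. Among the compounds with values here, no two measured compounds differ in a single place, so no one-change step is known. Compound 3 `CCCCn1c(=O)n(C2OC(CO)[C@@H](O)[C@H]2O)c2nc(N)nc(O)c21` has not yet been measured in this assay. It differs from compound 1 in one place: propyl in place of 2-azido-1-hydroxyethyl on a saturated chain carbon bound to an aromatic nitrogen. Within the data shown here, the only pointer is compound 2, whose 130% lies above that of compound 1, and compound 2 likewise carries only plain carbon chains on its core; on that basis a small rise is expected. Compound 3 is expected to give 105% in this assay, within 80% to 135%, an estimated step of a number 14 percentage points higher from compound 1 to compound 3 (beyond the scatter) that may well stay within the scatter.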

Compound 3, largest response reached (reported as maximal response), in percent of the reference or control that the assay uses: 86%
The estimate for compound 3 lay 19 percentage points above the measured number; the measured number falls inside the stated range.
By their numbers in this assay, from the lowest: compounds 3 and 1 (each within the scatter of the next); then compound 2.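

In this assay, within the data shown here, the exchange of 2-azido-1-hydroxyethyl for propyl, on a saturated chain carbon bound to an aromatic nitrogen, comes out as a number 5 percentage points lower from compound 1 to compound 3 (within the scatter) and is the first one-change step available for this series. At this place, then, a chain with azide and hydroxyl and a plain carbon chain cannot be told apart on this read-out, on the shared core of compound 1 and compound 3. Nothing at hand bears on why the two chains read alike.

On these data alone, since the azide and the hydroxyl leave together, their separate contributions stay open, as does the outcome with an amine, a carboxylic acid or a longer chain at this place. Steps involving compound 2 cannot be read, as it differs from compound 1 and compound 3 in more than one place.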